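Trimming the group on the aromatic nitrogen

The source may hold more compounds than are shown below. What is called first, only, known or untested is meant among the compounds shown, and "the series" means these compounds.

Measured in a physicochemical assay for solubility, measured as kinetic solubility; a higher number here means a more soluble compound, a lower number a less soluble compound:
- compound 1 `CC(=O)Nc1cc(-c2ccc(N(C)C(=O)c3c(F)cccc3Cl)c(N3CC4CC4C3)c2)n(C2CCCC2)n1`: 0.1 ug/mL
- compound 2 `CC(=O)Nc1cc(-c2ccc(N(C)C(=O)c3c(F)cccc3Cl)c(N3CC4CC4C3)c2)n(C(C)C)n1`: 2.1 ug/mL
- compound 3 `CC(=O)Nc1cc(-c2ccc(N(C)C(=O)c3c(F)cccc3Cl)c(N3CC4CC4C3)c2)n(C(C)C2CC2)n1`: 0.5 ug/mL

Among the three, compound 3 at 0.5 ug/mL stands in the middle, under compound 2 and over compound 1. Compound 4 `CC(=O)Nc1cc(-c2ccc(N(C)C(=O)c3c(F)cccc3Cl)c(N3CC4CC4C3)c2)n(CC2CC2)n1` has hydrogen in place of methyl on a saturated chain carbon bound to an aromatic nitrogen and a saturated ring carbon, so 1-cyclopropylethyl becomes cyclopropylmethyl. Among the compounds with values here, no measured step makes this exact change. The closest is a 4.2-fold lower number from compound 2 to compound 3 (0.62 log units; beyond the scatter), with cyclopropyl in place of methyl. Also relevant are a 21-fold higher number from compound 1 to compound 2 (1.32 log units; beyond the scatter) and a 5.0-fold higher number from compound 1 to compound 3 (0.70 log units; beyond the scatter), both replacing cyclopentyl. A modest rise in this assay is therefore expected, a 2.4-fold higher number from compound 3 to compound 4 (0.38 log units; beyond the scatter). Compound 4 is estimated at 1.2 ug/mL, with an expected range of 0.4 ug/mL to 3.5 ug/mL.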

Compound 4, solubility: 10.1 ug/mL
Beside the measured number, compound 4's estimate is 8.4-fold (0.93 log units) below it; the whole stated range lies below it.
By their numbers in this assay, from the lowest: compound 1; then compound 3; then compound 2; then compound 4.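

In this assay, hydrogen in place of methyl on a saturated chain carbon bound to an aromatic nitrogen and a saturated ring carbon gives a 20-fold higher number from compound 3 to compound 4 (1.31 log units; beyond the scatter), so this single replacement carries a large step. Cyclopropylmethyl also exceeds isopropyl and cyclopentyl, with a 4.8-fold higher number from compound 2 to compound 4 (0.68 log units; beyond the scatter) and a 100-fold higher number from compound 1 to compound 4 (2.00 log units; beyond the scatter), which leaves compound 4 highest of the four. No supporting measurement bears on the reason for this rise.

From the compounds shown here alone, whether ethyl or a methoxyethyl chain on the aromatic nitrogen would extend the rise remains open, as does whether the same replacement behaves alike on another core.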